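Phenyl to ester chain on the thioethyl arm

A few compounds are considered here, and "the series" means these few. Any claim that something is new, unique, unknown or untested is made for them only; others in the source may bear on it.

Three compounds share one core and differ in what hangs from the sulfur. Compound 1 `O=C(O)Cn1c(SCCOc2ccc3ccccc3c2)nc2ccccc21` gives 2500 nM in an assay on HEK293 cells for displacement of a labelled ligand from prostaglandin D2 receptor 2 (Homo sapiens); a lower number here means a stronger inhibitor, a higher number a weaker inhibitor. Compound 2 `O=C(O)Cn1c(SCCOc2cccc3ccccc23)nc2ccccc21` gives 2000 nM in this assay. Compound 3 `O=C(O)Cn1c(SCCc2ccccc2)nc2ccccc21` gives 881 nM in this assay, the lowest of the three numbers, and its separation from compound 2 and from compound 1 lies beyond the usual scatter, so compound 3 is the strongest inhibitor of the three.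

Compound 4 `CCOC(=O)CCCCSc1nc2ccccc2n1CC(=O)O` is not yet measured. It differs from compound 3 in one place: 2-(ethoxycarbonyl)ethyl in place of phenyl on a saturated chain carbon, two bonds along the chain from a sulfur. Among the compounds with values here, no measured pair reports a step of this kind, so the expectation rests on the fact that every measured compound so far carries an aromatic group on the arm and that the smallest one, in compound 3, gives the lowest number. Removing the aromatic group entirely is expected to weaken binding rather than improve it, with a step from compound 3 to compound 4 of a 4.0-fold higher number from compound 3 to compound 4 (0.60 log units; beyond the scatter) expected in this assay. Compound 4 is therefore estimated at 3500 nM, with a plausible range from 900 nM to 14000 nM.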

Compound 4, half-maximal inhibitory concentration: 2360 nM
Compound 4: middle estimate off by 1.5-fold (0.17 log units), on the high side; the measured number falls inside the stated range.
By their numbers in this assay, from the lowest: compound 3; then compounds 2, 4 and 1 (each within the scatter of the next).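

The saturated chain carbon, two bonds along the chain from a sulfur, does not need an aromatic ring for a measurable number: in this assay, 2-(ethoxycarbonyl)ethyl in place of phenyl gives a 2.7-fold higher number from compound 3 to compound 4 (0.43 log units; beyond the scatter), a modest step beyond the scatter. Phenyl retains the lower number of this pair, but the change removes a ring and adds 2 hydrogen-bond acceptors at once, so the two contributions cannot be separated here. No measured evidence accounts for the size of this step.

Still open, going by these compounds, is whether the ester oxygens or the loss of the ring sets the step; a plain alkyl chain or a cyclohexyl group at this place would address that. On these data alone, a carboxylic acid in place of the ethyl ester also remains open.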